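Bombesin receptor subtype-3 agonists: alkyl for benzyl at the imidazole

The source may report more compounds than this note shows. Statements on the series, on what has been measured and on what is new or still open speak of the compounds shown alone.

Measured so far:
compound 1 `O=C(O)c1ccccc1-c1ccc(CCc2ncc(CC3CCCC3)[nH]2)cc1`: 7.9 nM
compound 2 `O=C(O)c1ccccc1-c1ccc(CCc2ncc(Cc3ccccc3Cl)[nH]2)cc1`: 22 nM
compound 3 `O=C(O)c1ccccc1-c1ccc(CCc2ncc(Cc3cccc(F)c3)[nH]2)cc1`: 7.9 nM

All three share one core and differ only in the group on the saturated chain carbon bound to the five-membered ring. Within the data shown here, in an in vitro functional assay on cells for agonist activity at Bombesin receptor subtype-3 (Mus musculus), read by luminescence and calcium flux (on this read-out higher numbers stand for an effect only at larger amounts of compound and lower numbers for an effect already at smaller amounts), compound 3 gives 7.9 nM, level with compound 1 and together with it the lowest of the three numbers; the one step beyond the scatter is a 2.8-fold lower number from compound 2 to compound 3 (0.44 log units; beyond the scatter).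

Compound 4 `CC(C)(C)c1cnc(CCc2ccc(-c3ccccc3C(=O)O)cc2)[nH]1` removes the chain carbon altogether: tert-butyl in place of 3-fluorobenzyl on an aromatic carbon.

Among the measured compounds shown here, two steps bear on this, though neither is the same kind of change. no change at the digits printed from compound 1 to compound 3 (within the scatter) shows that a saturated ring and a fluorinated aromatic ring on that chain carbon are interchangeable within the scatter. a 2.8-fold higher number from compound 1 to compound 2 (0.44 log units; beyond the scatter) shows that the choice of aromatic ring can move the number modestly. For the measured compounds named here, no measured pair removes the chain carbon or puts a branched saturated group straight onto the ring, so the data give no direct reading of that move. Given that the saturated cyclopentyl of compound 1 matches compound 3, a small saturated group is expected to stay in the same region, with a modest rise in the number as the more likely direction, giving a 2.5-fold higher number from compound 3 to compound 4 (0.40 log units; beyond the scatter).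

Estimate for compound 4 in this assay: 20 nM (range 5 nM to 80 nM).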

Compound 4, half-maximal effective concentration: 2750 nM
Compound 4: middle estimate off by 140-fold (2.14 log units), on the low side; measured number outside the range, above it.
By their numbers in this assay, from the lowest: compounds 1 and 3 (each within the scatter of the next); then compound 2; then compound 4.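

In this assay, among these compounds, this position proves far less tolerant than the earlier compounds suggested: across cyclopentylmethyl, 2-chlorobenzyl and 3-fluorobenzyl, the number moved modestly at most, whereas tert-butyl on the aromatic carbon brings a large rise (a 350-fold higher number from compound 3 to compound 4 (2.54 log units; beyond the scatter)) and a similarly large one from the chlorinated benzyl compound (a 130-fold higher number from compound 2 to compound 4 (2.10 log units; beyond the scatter)). The loss does not depend on leaving an aromatic ring behind, since replacing the fully saturated cyclopentylmethyl gives a step of the same printed size as replacing 3-fluorobenzyl (a 350-fold higher number from compound 1 to compound 4 (2.54 log units; beyond the scatter)), so being saturated does not by itself decide the outcome among these groups. No measurement available here accounts for the loss.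

This single change removes the chain carbon and also replaces a larger group with tert-butyl, which has fewer heavy atoms, so the compounds shown do not separate those two differences. Neopentyl, which keeps a chain carbon and carries tert-butyl on it, and cyclopentyl or phenyl placed directly on the aromatic carbon would show which of the two differences tracks with the rise in the number.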